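The source may hold more compounds than are shown below. What is called first, only, known or untested is meant among the compounds shown, and "the series" means these compounds.

Compound 1, with the structure `COc1ccc(Cn2cc(CO/N=C/c3c(-c4ccccc4)nc4c(C)cccn34)nn2)cc1`, gives 100 mg/kg in a functional assay on the whole organism (strain NMRI) with Mus musculus as the target, with a stated time of 4 h (on this read-out lower numbers stand for an effect already at smaller amounts and higher numbers for an effect only at larger amounts of compound), which is the highest of the two numbers recorded so far. For the measured compounds named here, its nearest neighbour, compound 2, with the structure `Cc1cccn2c(/C=N/OCc3cn(Cc4ccc(C#N)cc4)nn3)c(-c3ccccc3)nc12`, gives 40 mg/kg in this assay, and the single measured step, a 2.5-fold lower number from compound 1 to compound 2 (0.40 log units; beyond the scatter), goes with cyano in place of methoxy on an aromatic carbon.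

Compound 3, with the structure `COc1ccc(Cn2cc(CO/N=C/c3c(-c4ccc(F)cc4)nc4c(C)cccn34)nn2)cc1`, has not yet been measured. It differs from compound 1 by fluoro in place of hydrogen on an aromatic carbon. Going by the values given here, no measured step bears directly on this change: the only step at hand, from compound 1 to compound 2, concerns a different group on a different ring, so it offers no guide to what a fluoro in place of hydrogen does here. With nothing pointing in either direction, compound 3 is expected to stay close to compound 1, with the step of no change at the digits printed from compound 1 to compound 3 (within the scatter) falling within the usual scatter. The estimate for compound 3 in this assay is therefore 100 mg/kg, with a range from 40 mg/kg to 250 mg/kg.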

Compound 3, minimum effective dose: 40 mg/kg
The estimate for compound 3 lay 2.5-fold (0.40 log units) above the measured number; the range from low to high includes it.
By their numbers in this assay, from the lowest: compounds 2 and 3 (each within the scatter of the next); then compound 1.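

The phenyl group on the shared core, untouched by the earlier step, also matters in this assay: phenyl to 4-fluorophenyl goes with a 2.5-fold lower number from compound 1 to compound 3 (0.40 log units; beyond the scatter) and so lies beyond the scatter, even though the entering group is a single fluorine atom on an aromatic carbon, para to a large group. The earlier step, a 2.5-fold lower number from compound 1 to compound 2 (0.40 log units; beyond the scatter), concerned cyano in place of methoxy on a different ring, so the number of compound 1 has now been seen to fall with a change at either of two separate places. The data at hand hold no measurement that speaks to the reason for the new step.

As far as these compounds go, whether this step is particular to fluoro remains open, since a chloro group, a hydroxyl group or an amine in the same place on the six-membered aromatic ring would show how far the result extends beyond this one substituent. From the compounds shown here alone, it is also open whether the two changes add up when 4-fluorophenyl and cyano stand together in one molecule, or whether the second brings nothing further in this read-out.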